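This account rests on a few compounds, and the source may have more. Where it says the series, first, only, none or still open, it means among the compounds named here.

Measured compounds in an assay on HEK293 cells for activation of potassium channel subfamily T member 1 (Homo sapiens), read by thallium flux; a lower number here means that less compound is needed, a higher number that more compound is needed for the effect:
- compound 1, `COc1ccc(Cl)cc1NC(=O)N1CC2(CCN(S(=O)(=O)N3CCC(C)CC3)CC2)C1`: compound 1 reports > 10000 nM, a limit of the assay.
- compound 2, `CC1CCN(S(=O)(=O)N2CCN(CC(=O)Nc3cccc(Cl)c3)CC2)CC1`: compound 2 gives 7600 nM.
- compound 3, `COc1ccc(Cl)cc1NC(=O)CN1CCN(S(=O)(=O)N2CCN(C(=O)N3CCCCCC3)CC2)CC1`: compound 3 reports > 10000 nM, again a limit of the assay.

For the measured compounds named here, compound 2 is thus the only compound of the three with a numerical result in this assay; the other two sit at the limit of > 10000 nM in this assay, at which 2 of the 3 values shown sit, so no step between measured compounds can be counted, and the position of compound 2 relative to the rest of the series rests on that single number.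

The next compound, compound 4, has the structure `CC1CCN(S(=O)(=O)N2CCN(CC(=O)Nc3ccccc3F)CC2)CC1`. It keeps the core of compound 2 and changes only the aryl group on the amide-type nitrogen: 2-fluorophenyl in place of 3-chlorophenyl on an amide-type nitrogen, that is, 2-fluorophenyl in place of 3-chlorophenyl. Going by the values given here, with no measured step in hand, nothing says which way this change moves the read-out. The expectation is a small step toward a higher number, of a size at or just beyond the usual scatter, with a real chance that compound 4 ends at the same limit as compound 1 and compound 3.

For compound 4 the estimate in this assay is 12000 nM, with a range from 4000 nM to 40000 nM. The expected step from compound 2 to compound 4 is therefore a 1.6-fold higher number from compound 2 to compound 4 (0.20 log units; within the scatter).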

Compound 4, half-maximal effective concentration: > 10000 nM
Compound 4 ended at the assay's limit; the forecaster's own chance of this, stated with the estimate: 55%; the middle value is on the limit's open side.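

Compound 4 reports > 10000 nM, a limit of the assay and not a number. In this assay, for the compounds shown here, 2-fluorophenyl in place of 3-chlorophenyl on the amide-type nitrogen gives the first readable step, an at least 1.3-fold higher number from compound 2 to compound 4 (0.11 log units; that floor lies within the scatter), so this is only a floor, the true size of the step is unknown, and the data do not establish a real change at this position. The swap also leaves compound 2 as the only compound shown with a numerical result, and the series now gives little room for reading further changes: the limit of > 10000 nM in this assay, at which 3 of the 4 values shown sit.

The step changes both the halogen and its place on the ring, and the compounds shown do not separate the two, so 3-fluorophenyl and 2-chlorophenyl would be needed to tell which of them matters. Also open, on these data alone, is whether any other group on the amide-type nitrogen, such as unsubstituted phenyl or a phenyl ring carrying a carboxylic acid or an amine, gives a number clearly lower than that of compound 2 at 7600 nM.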